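From a Carbamoyl to a Hydroxycarbamoyl Group

A few compounds are considered here, and "the series" means these few. Any claim that something is new, unique, unknown or untested is made for them only; others in the source may bear on it.

Three measured compounds share one core and differ only in the group on an aromatic carbon. In a functional assay on MOLM-13 cells (Homo sapiens) for antiproliferative activity (on this read-out lower numbers stand for stronger inhibition and higher numbers for weaker inhibition), compound 1 `Cc1c(-c2ccc(-c3ccccc3F)cc2)nc2ccc(F)cc2c1-c1noc(=O)[nH]1` gives > 3000 nM and this value is a limit of the assay, not a number. In this assay compound 2 `Cc1c(-c2ccc(-c3ccccc3F)cc2)nc2ccc(F)cc2c1C(N)=O` gives 128 nM and compound 3 `Cc1c(-c2ccc(-c3ccccc3F)cc2)nc2ccc(F)cc2c1C(=O)NS(C)(=O)=O` gives 300 nM in the same test. Compound 2 therefore holds the lower of the two true numbers and is the best performer so far.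

Giving up the five-membered ring of compound 1 produced an at least 23-fold lower number from compound 1 to compound 2 (1.36 log units; beyond the scatter) in one case and an at least 10-fold lower number from compound 1 to compound 3 (1.00 log units; beyond the scatter) in the other. Those steps replace a whole group, so they say little about a small edit. Closer is a 2.3-fold higher number from compound 2 to compound 3 (0.37 log units; beyond the scatter) where methylsulfonyl takes the place of hydrogen on an amide-type nitrogen.

Within the data shown here, compound 4 `Cc1c(-c2ccc(-c3ccccc3F)cc2)nc2ccc(F)cc2c1C(=O)NO` alters that same nitrogen, with hydroxy in place of hydrogen on an amide-type nitrogen as its only difference from compound 2. With one precedent on this nitrogen, a similar modest rise is expected, and it may prove no larger than the scatter. The expected change is a 1.7-fold higher number from compound 2 to compound 4 (0.24 log units; within the scatter) and its direction remains uncertain. For compound 4 the estimate is 220 nM with an expected range of 70 nM to 800 nM in this assay once measured.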

Compound 4, half-maximal inhibitory concentration: 23 nM
Beside the measured number, compound 4's estimate is 9.6-fold (0.98 log units) above it, outside the stated range (below it).
By their numbers in this assay, from the lowest: compound 4; then compound 2; then compound 3. At a limit, above all of these: compound 1.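

In this assay, among these compounds, the earlier compounds showed only a rise in the number when the amide hydrogen was replaced, whereas hydroxy on the same nitrogen gives a 5.6-fold lower number from compound 2 to compound 4 (0.75 log units; beyond the scatter), so a change at this nitrogen can move the number either way. What enters therefore matters, not just the loss of the hydrogen: swapping methylsulfonyl for hydroxy gives a 13-fold lower number from compound 3 to compound 4 (1.12 log units; beyond the scatter), and replacing the five-membered ring of compound 1 with the hydroxycarbamoyl group gives an at least 130-fold lower number from compound 1 to compound 4 (2.11 log units; beyond the scatter). Compound 1 sits at a limit of the assay rather than at a true number, so that last step is only a bound on the real size: the limit of > 3000 nM in this assay, at which 1 of the 4 values shown sits.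

Only hydrogen, hydroxy and methylsulfonyl can be compared on this nitrogen, so the compounds shown cannot tell whether the gain depends on the hydroxy group itself or would also appear with another small group. A methoxy or methyl group on the same nitrogen, or a carboxylic acid in place of the whole carbamoyl group, would address this, and the reason for the gain remains open.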